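Methoxy for Hydrogen: an Expected Antiproliferative Outcome

This account rests on a few compounds, and the source may have more. Where it says the series, first, only, none or still open, it means among the compounds named here.

Compound 1 `COc1ccc(-c2nc(C)c(C(=O)CSc3nc(N)c(C#N)c(-c4ccc(Cl)cc4)n3)s2)cc1` gives 51.4% in a functional assay on U-87MG ATCC cells for antiproliferative activity against U-87 MG (Homo sapiens), read by MTT assay, with a stated time of 48 h, tested at 5 uM; a lower number here means a stronger effect, a higher number a weaker effect of the compound at the concentration tested.
Compound 2 `COc1ccc(-c2nc(C)c(C(=O)CSc3nc(N)c(C#N)c(-c4ccccc4)n3)s2)cc1` gives 61.8% in this assay.

Within the data shown here, compound 2 holds the highest of the two numbers in this assay; its nearest neighbour is compound 1, and the single step of a number 10.4 percentage points higher from compound 1 to compound 2 (beyond the scatter) was beyond the scatter but modest. Compound 3 `COc1ccc(-c2nc(C)c(C(=O)CSc3nc(N)c(C#N)c(-c4ccc(OC)cc4)n3)s2)cc1` differs from compound 2 as follows: methoxy in place of hydrogen on an aromatic carbon. Among the measured compounds shown here, no measured step involves a methoxy group, so that chloro step bears only loosely on this change. Compound 3 is therefore expected to give 60% in this assay, within 42% to 78%, and the expected step of a number 1.8 percentage points lower from compound 2 to compound 3 (within the scatter) is estimated to stay within the scatter.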

Compound 3, a percentage reported as activity, at one concentration (the size of the read-out at that concentration, not a potency): 35.6%
Beside the measured number, compound 3's estimate is 24.4 percentage points above it; measured number outside the range, below it.
By their numbers in this assay, from the lowest: compound 3; then compound 1; then compound 2.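

The change from phenyl to 4-methoxyphenyl gives a number 26.2 percentage points lower from compound 2 to compound 3 (beyond the scatter) in this assay, and methoxy in place of chloro gives a number 15.8 percentage points lower from compound 1 to compound 3 (beyond the scatter) as well. This position therefore responds to which group it carries, not only to whether hydrogen is replaced, and compound 3 shows the strongest effect of the three at the concentration tested. Nothing available explains why methoxy gives the lowest number here.

The compounds shown leave open whether an amine or a longer chain such as ethoxy at this place would go further. They also leave open whether methoxy would give a similar step elsewhere on this ring.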